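The source may hold more compounds than are shown below. What is called first, only, known or untested is meant among the compounds shown, and "the series" means these compounds.

Working notes on the series. Of the compounds shown here, three have been measured in a functional assay on A549 cells (Homo sapiens) for antiproliferative activity, read by MTT assay, with a stated time of 48 h; on this read-out lower numbers stand for stronger inhibition and higher numbers for weaker inhibition. Compound 1 `FC(F)(F)c1ccc2[nH]c(-c3cn(-c4ccccc4)nc3-c3ccccc3)nc2c1` gives 5930 nM in this assay. Compound 2 `O=C(OCc1ccccc1)c1ccc2[nH]c(-c3cn(-c4ccccc4)nc3-c3ccccc3)nc2c1` carries the change benzyloxycarbonyl in place of trifluoromethyl on an aromatic carbon relative to compound 1, and in this assay compound 2 gives 19300 nM; the step is a 3.3-fold higher number from compound 1 to compound 2 (0.51 log units; beyond the scatter). Compound 3 `Fc1ccc(-c2nn(-c3ccccc3)cc2-c2nc3cc(C(F)(F)F)ccc3[nH]2)cc1` gives 2340 nM in this assay, and the step is a 2.5-fold lower number from compound 1 to compound 3 (0.40 log units; beyond the scatter). Compound 3 thus holds the lowest number of the three, with compound 1 nearest and compound 2 furthest.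

Compound 4 `O=C(OCc1ccccc1)c1ccc2[nH]c(-c3cn(-c4ccccc4)nc3-c3ccc(F)cc3)nc2c1` awaits measurement in this assay. It differs from compound 3 by benzyloxycarbonyl in place of trifluoromethyl on an aromatic carbon. Within the data shown here, this is the same change, at the same place described in the same words, as the one already measured from compound 1 to compound 2, so the two changes are the same. The two cores on which it is made differ by fluoro in place of hydrogen on an aromatic carbon.

Among the measured compounds shown here, with only one earlier instance of this change, the expectation for compound 4 rests on that instance: the step from compound 3 to compound 4 is expected to be a 3.3-fold higher number from compound 3 to compound 4 (0.52 log units; beyond the scatter), set beside a 3.3-fold higher number from compound 1 to compound 2 (0.51 log units; beyond the scatter), because a 3.3-fold higher number from compound 1 to compound 2 (0.51 log units; beyond the scatter) is the only measured guide. For the measured compounds named here, on that basis compound 4 is expected to give about 7700 nM in this assay, with the estimate spanning 3500 nM to 17000 nM; the single precedent leaves the range wide.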

Compound 4, half-maximal inhibitory concentration: 21500 nM
Compound 4: middle estimate off by 2.8-fold (0.45 log units), on the low side; the whole stated range lies below it.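

In this assay the change from trifluoromethyl to benzyloxycarbonyl again goes toward a higher number (a 9.2-fold higher number from compound 3 to compound 4 (0.96 log units; beyond the scatter)), so its direction carries from the core of compound 1 to the core of compound 3, but its size does not: the same change on two cores in this assay, a 3.3-fold higher number (0.51 log units; beyond the scatter) from compound 1 to compound 2 and a 9.2-fold higher number (0.96 log units; beyond the scatter) from compound 3 to compound 4, 2.8-fold (0.45 log units) apart, beyond the scatter of two such steps

Read the other way, fluoro in place of hydrogen lowers the number when trifluoromethyl is present but gives no difference beyond the scatter when benzyloxycarbonyl is present (a 1.1-fold higher number from compound 2 to compound 4 (0.05 log units; within the scatter)), so the advantage of compound 3 over compound 1 does not reach compound 4: the same change on two cores in this assay, a 2.5-fold lower number (0.40 log units; beyond the scatter) from compound 1 to compound 3 and a 1.1-fold higher number (0.05 log units; within the scatter) from compound 2 to compound 4, 2.8-fold (0.45 log units) apart, beyond the scatter of two such steps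

These two pairs show that the two changes do not act independently across these four compounds, but they do not show why, and they do not establish how either change would behave on any other core.

It remains open whether the behaviour belongs to the whole benzyloxycarbonyl group or to a part of it, since the compounds shown include no methyl ester, carboxylic acid or amide at that place. Among these compounds, it also remains open whether fluoro is special among replacements for that hydrogen, since no chloro or methoxy compound stands beside it.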